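Oral exposure across imide-type side chain variants

The compounds below may be only part of what the source reports. "The series", "measured", "known", "first", "only" and "open" are said of these compounds alone.

Measured compounds:
compound 1 `C=CCNC(=O)C(=O)[C@@H]1CCCCCCCCC[C@H](NC(=O)N[C@H](CN2C(=O)CC(C)(C)CC2=O)C(C)(C)C)C(=O)N2C[C@@H]3[C@H]([C@H]2C(=O)N1)C3(C)C` gives 800 ng.h/mL
compound 2 `C=CCNC(=O)C(=O)[C@@H]1CCCCCCCCC[C@H](NC(=O)N[C@H](CN2CCC(C)(C)CC2=O)C(C)(C)C)C(=O)N2C[C@@H]3[C@H]([C@H]2C(=O)N1)C3(C)C` gives 1070 ng.h/mL
compound 3 `C=CCNC(=O)C(=O)[C@@H]1CCCCCCCCC[C@H](NC(=O)N[C@H](CN2C(=O)c3ccccc3C2=O)C(C)(C)C)C(=O)N2C[C@@H]3[C@H]([C@H]2C(=O)N1)C3(C)C` gives 880 ng.h/mL

All three values come from an ADME assay on the whole organism (plasma) for pharmacokinetics, with Rattus norvegicus as the target, with a stated time of 6 h, at a dose of 10 mg/kg by the oral route; a lower number here means less compound in the circulation, a higher number more compound in the circulation at the dose given. Compound 3 stands second highest of the three numbers, but its nearest neighbour is compound 1 at a 1.1-fold higher number from compound 1 to compound 3 (0.04 log units; within the scatter) and its furthest is compound 2 at a 1.2-fold lower number from compound 2 to compound 3 (0.08 log units; within the scatter), so no ordering among the three can be read from these values. Likewise a 1.3-fold higher number from compound 1 to compound 2 (0.13 log units; within the scatter) shows no separation between compounds 1 and 2.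

Compound 4 `C=CCNC(=O)C(=O)[C@@H]1CCCCCCCCC[C@H](NC(=O)N[C@H](CN2C(=O)CN(C)CC2=O)C(C)(C)C)C(=O)N2C[C@@H]3[C@H]([C@H]2C(=O)N1)C3(C)C` is not yet measured in this assay. Relative to compound 3 the change is a group of 9 heavy atoms (5 carbon, 2 nitrogen, 2 oxygen; one six-membered non-aromatic ring with 2 hetero atoms) in place of a group of 11 heavy atoms (8 carbon, 1 nitrogen, 2 oxygen; one five-membered non-aromatic ring with 1 hetero atom, one six-membered aromatic ring of carbon only), on a saturated chain carbon, two bonds along the chain from an amide-type nitrogen. For the measured compounds named here, the steps that bear on it are those exchanging the group on the same chain carbon: a 1.1-fold higher number from compound 1 to compound 3 (0.04 log units; within the scatter) and a 1.2-fold lower number from compound 2 to compound 3 (0.08 log units; within the scatter), both within the scatter, as is a 1.3-fold higher number from compound 1 to compound 2 (0.13 log units; within the scatter). Three such exchanges at this position have left the area under the curve unchanged within scatter, so for compound 4 no step beyond the scatter is expected, and the expected step is a 1.1-fold lower number from compound 3 to compound 4 (0.04 log units; within the scatter). Compound 4 is therefore estimated at 800 ng.h/mL, with a range of 350 ng.h/mL to 1800 ng.h/mL.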

Compound 4, area under the concentration-time curve: 200 ng.h/mL
Beside the measured number, compound 4's estimate is 4.0-fold (0.60 log units) above it, and the stated range ends above it.
By their numbers in this assay, from the lowest: compound 4; then compounds 1, 3 and 2 (each within the scatter of the next).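

In this assay, for the compounds shown here, this chain carbon is no longer indifferent to the group it carries: 4-methyl-2,6-dioxopiperazin-1-yl gives the first exchanges here that leave the scatter (a 4.0-fold lower number from compound 1 to compound 4 (0.60 log units; beyond the scatter); a 5.4-fold lower number from compound 2 to compound 4 (0.73 log units; beyond the scatter); a 4.4-fold lower number from compound 3 to compound 4 (0.64 log units; beyond the scatter)). The three earlier groups stay within the scatter of one another despite differing in carbonyl count and in the presence of an aromatic ring, so neither of those features alone tracks the lower exposure among the compounds shown; the entering group is the only one with a second ring nitrogen. No evidence on the cause of this drop is at hand.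

Still open, as far as these compounds go, is whether the drop follows the methyl-bearing ring nitrogen or the entering ring as a whole. A morpholine-3,5-dione group, with a ring oxygen in place of that nitrogen, or an unsubstituted piperazine-2,6-dione on the same chain carbon would bear on this.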